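Amino Replaces Methyl on the Shared Purine-Type Core

The source may report more compounds than this note shows. Statements on the series, on what has been measured and on what is new or still open speak of the compounds shown alone.

Compound 2 `Cc1nc(N)c2nc(O)n(Cc3ccccc3)c2n1` gives 1 uM in a functional assay (spleen, spleen) for activation, with Mus musculus as the target (on this read-out lower numbers stand for an effect already at smaller amounts and higher numbers for an effect only at larger amounts of compound), the highest of the two numbers measured; its nearest neighbour, compound 1 `CCCNc1nc(N)c2nc(O)n(Cc3ccccc3)c2n1`, gives 0.1 uM. Compound 3 `Nc1nc(N)c2nc(O)n(Cc3ccccc3)c2n1` differs from compound 2 by amino in place of methyl on an aromatic carbon. Within the data shown here, the one step that bears on this site is a 10-fold higher number from compound 1 to compound 2 (1.00 log units; beyond the scatter), a modest loss when the propylamino was taken away. Amino restores a donor and acceptor there without the propyl chain, so a partial recovery is expected: a 2.5-fold lower number from compound 2 to compound 3 (0.40 log units; beyond the scatter). Compound 3 is therefore estimated at 0.4 uM, with a range from 0.1 uM to 2 uM.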

Compound 3, minimum effective concentration: 10 uM
Compound 3: the middle estimate sits 25-fold (1.40 log units) below what was measured; the measured number lies above the stated range.
By their numbers in this assay, from the lowest: compound 1; then compound 2; then compound 3.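

In this assay, amino on this aromatic carbon gives a 10-fold higher number from compound 2 to compound 3 (1.00 log units; beyond the scatter) when it replaces methyl, so it does not fall between methyl and propylamino. Removing propyl from the nitrogen gives a 100-fold higher number from compound 1 to compound 3 (2.00 log units; beyond the scatter) on the same carbon, the largest step among these three compounds, and the order runs propylamino, methyl, amino. Nothing on hand accounts for this order.

As far as these compounds go, whether a longer chain on that nitrogen, such as butylamino, or a dimethylamino group or an ethyl on this carbon would extend the order remains open.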